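Taking the hydroxy off compound 3

The compounds below may be only part of what the source reports. "The series", "measured", "known", "first", "only" and "open" are said of these compounds alone.

In a functional assay on HepG2 cells (Homo sapiens) for antiproliferative activity, read by fluorescence and resazurin assay, with a stated time of 48 h (a higher number here means a weaker inhibitor, a lower number a stronger inhibitor), compound 1 `Cc1noc(NS(=O)(=O)c2ccc(NC(=O)c3cc4ccc(O)cc4oc3=O)cc2)c1C` gives a modest value (38800 nM), and compound 2 `CCOc1ccc(NC(=O)c2cc3cc(Br)ccc3oc2=O)cc1` gives one within the scatter of it (37000 nM). Compound 3 `O=C(N/N=C/c1cccnc1)c1cc2ccc(O)cc2oc1=O` reads (18400 nM). That number lies within the scatter of compound 2 and only just beyond the scatter on the stronger side of compound 1. Compound 4 `O=C(N/N=C/c1cccnc1)c1cc2ccccc2oc1=O` is compound 3 with hydrogen in place of hydroxy on an aromatic carbon. Within the data shown here, no measured pair shows this change, so the data give no size for it in this assay, and no step beyond the scatter is expected in either direction. The expected step is small (a 1.1-fold higher number from compound 3 to compound 4 (0.04 log units; within the scatter)). Compound 4 is estimated at 20000 nM (expected range 8000 nM to 50000 nM).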

Compound 4, half-maximal inhibitory concentration: 15900 nM
Beside the measured number, compound 4's estimate is 1.3-fold (0.10 log units) above it, and the stated range covers the measured number.
By their numbers in this assay, from the lowest: compounds 4, 3, 2 and 1 (each within the scatter of the next, the first and the last beyond it).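

Taking off the hydroxy gives a 1.2-fold lower number from compound 3 to compound 4 (0.06 log units; within the scatter) in this assay, the first measured size for this change. With the rest of compound 3 held fixed, the hydroxy on this aromatic carbon is therefore not needed to keep the antiproliferative reading. Nothing available explains the size of this step.

From the compounds shown here alone, whether another group on this carbon, such as an amine or a methoxy group, would shift the number beyond the scatter remains open. So does whether removing the same hydroxy from compound 1 would prove as small.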